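The source may hold more compounds than are shown below. What is called first, only, known or untested is meant among the compounds shown, and "the series" means these compounds.

Measured so far:
compound 1 `Cc1noc(C)c1-c1cnc(N)c(Oc2ccc(C(=O)Nc3ccccc3Cl)cc2)n1` gives 81300 nM in a functional assay on HeLa cells (Homo sapiens) for inhibition, read by MTT assay, with a stated time of 72 h; on this read-out higher numbers stand for weaker inhibition and lower numbers for stronger inhibition
compound 2 `Cn1cc(-c2cnc(N)c(Oc3ccc(C(=O)Nc4ccccc4Cl)cc3)n2)cn1` gives 73000 nM in this assay

On these numbers compound 2 cannot be told apart from compound 1: a 1.1-fold lower number from compound 1 to compound 2 (0.05 log units; within the scatter). Compound 3 `Cn1cc(-c2cnc(N)c(Oc3ccc(C(=O)Nc4ccc(Cl)cn4)cc3)n2)cn1` differs from compound 2 by 5-chloropyridin-2-yl in place of 2-chlorophenyl on an amide-type nitrogen. Among the measured compounds shown here, the one measured step alters a different part of the molecule, so nothing measured bears directly on a change at the amide nitrogen, and both known numbers sit close together. In this assay compound 3 is therefore expected to show no step beyond the scatter, a 1.0-fold lower number from compound 2 to compound 3 (0.02 log units; within the scatter). The estimate for compound 3 is 70000 nM, with a range from 25000 nM to 200000 nM.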

Compound 3, half-maximal inhibitory concentration: 21500 nM
Estimate against measurement, compound 3: 3.3-fold (0.51 log units) above; the whole stated range lies above it.
By their numbers in this assay, from the lowest: compound 3; then compounds 2 and 1 (each within the scatter of the next).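

In this assay, swapping the group on the amide-type nitrogen gives a 3.4-fold lower number from compound 2 to compound 3 (0.53 log units; beyond the scatter), a modest step but beyond the scatter. This position therefore responds to change, unlike the aromatic carbon altered in a 1.1-fold lower number from compound 1 to compound 2 (0.05 log units; within the scatter), where the step stays within the scatter. No measurement available here explains the gain.

On these data alone, the swap adds a ring nitrogen and gives the chlorine a different place, so which of these matters stays open. So does the effect of unsubstituted pyridin-2-yl, or of 5-methoxypyridin-2-yl, at this position.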